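Cutting the Chain Back to the Ring

The source may report more compounds than this note shows. Statements on the series, on what has been measured and on what is new or still open speak of the compounds shown alone.

Of the compounds shown here, three sharing one core have been tested in a functional assay on MDA-MB-231 cells (Homo sapiens) for inhibition, read by MTT assay, with a stated time of 48 h; on this read-out higher numbers stand for weaker inhibition and lower numbers for stronger inhibition. There, compound 1 (`COc1ccc(N(C)c2nc(C)nc3ccccc23)cc1C(=O)OCC[Se]C#N`) gives 1480 nM, compound 2 (`COc1ccc(N(C)c2nc(C)nc3ccccc23)cc1C(=O)OCCCC[Se]C#N`) gives 554 nM, and compound 3 (`COc1ccc(N(C)c2nc(C)nc3ccccc23)cc1OCCCC[Se]C#N`) gives 1350 nM. The numbers show a 1.1-fold lower number from compound 1 to compound 3 (0.04 log units; within the scatter), which leaves those two level, and a 2.4-fold higher number from compound 2 to compound 3 (0.39 log units; beyond the scatter).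

Compound 4 (`COc1ccc(N(C)c2nc(C)nc3ccccc23)cc1[Se]C#N`) differs from compound 3 by a group of 3 heavy atoms (1 carbon, 1 nitrogen, 1 selenium; no ring) in place of a group of 8 heavy atoms (5 carbon, 1 nitrogen, 1 oxygen, 1 selenium; no ring), on an aromatic carbon, on an aromatic carbon of a six-membered aromatic ring of carbon only, ortho to a methoxy group. The closest guide is a 2.7-fold lower number from compound 1 to compound 2 (0.43 log units; beyond the scatter), a modest step in which the shorter chain carries the higher number. Compound 3 goes against any simple chain-length rule, since its value sits level with that of compound 1 despite its longer chain. For the measured compounds named here, no tested compound has the selenium-bearing group directly on the ring, so the guide is weak.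

In this assay, only a small move towards a higher number is therefore expected. The expected change is a 1.3-fold higher number from compound 3 to compound 4 (0.10 log units; within the scatter). Compound 4 is estimated at 1700 nM, with an expected range of 500 nM to 5500 nM.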

Compound 4, half-maximal inhibitory concentration: 52 nM
The estimate for compound 4 lay 33-fold (1.51 log units) above the measured number; the measured number lies below the stated range.
By their numbers in this assay, from the lowest: compound 4; then compound 2; then compounds 3 and 1 (each within the scatter of the next).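

In this assay, taking the whole chain off this aromatic carbon, ortho to a methoxy group, and leaving only the group of 3 heavy atoms gives a far lower number than any of the chain-bearing compounds (a 26-fold lower number from compound 3 to compound 4 (1.41 log units; beyond the scatter)) (an 11-fold lower number from compound 2 to compound 4 (1.03 log units; beyond the scatter)) (a 28-fold lower number from compound 1 to compound 4 (1.45 log units; beyond the scatter)). For the compounds shown here, this drop is much larger than the modest change seen earlier between the two chains (a 2.7-fold lower number from compound 1 to compound 2 (0.43 log units; beyond the scatter)), so compound 4 has the lowest number of the four, and the earlier compounds gave no sign of this. Nothing at hand explains why the number falls so sharply.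

The compounds shown leave open whether selenium is needed, as a sulfur atom in its place would test. They also leave open whether a single carbon between the ring and the selenium keeps the low number.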